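This account rests on a few compounds, and the source may have more. Where it says the series, first, only, none or still open, it means among the compounds named here.

Two compounds in this series have been taken through a functional assay on the whole organism (strain albino) for inhibition, with Rattus norvegicus as the target, read by paw edema, with stated times of 1 h and 3 h, at a dose of 200 mg/kg by the oral route; a lower number here means a weaker effect, a higher number a stronger effect of the compound at the dose given. Compound 1, `Cn1c(SCC(=O)Nn2c(COc3ccc(Cl)cc3Cl)nc3ccccc3c2=O)nc(-c2ccc(O)cc2)c(C#N)c1=O`, gives 97.8% in this assay. Compound 2, `N#Cc1c(Nc2ccc(O)cc2)nc(SCC(=O)Nn2c(COc3ccc(Cl)cc3Cl)nc3ccccc3c2=O)nc1-c1ccc(Cl)cc1`, gives 96.5% in this assay. Of the two numbers that of compound 2 is the lower, but the two values lie within the usual scatter of each other, so nothing can be said about an order between them; both point to a strong effect at the dose given.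

Compound 3, `N#Cc1c(Nc2ccc(O)cc2)nc(SCC(=O)Nn2c(COc3ccc(Cl)cc3Cl)nc3ccccc3c2=O)nc1-c1ccc(O)cc1`, has not yet been measured. It differs from compound 2 by hydroxy in place of chloro on an aromatic carbon, on an aromatic carbon of a six-membered aromatic ring of carbon only. Within the data shown here, with no measured pair in hand that shows this exact change, the expectation for compound 3 rests on the two values seen so far, both of which sit near the top of the read-out. The step expected from compound 2 to compound 3 in this assay is a number 0.5 percentage points lower from compound 2 to compound 3 (within the scatter), which is to say none beyond the scatter. Compound 3 is therefore estimated at 96% in this assay, within a range from 86% to 99%.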

Compound 3, a percentage reported as inhibition, in the whole organism at one dose (the size of the read-out at that dose, not a potency): 91.2%
Compound 3: the middle estimate sits 4.8 percentage points above what was measured, within the range that was stated.
By their numbers in this assay, from the lowest: compounds 3, 2 and 1 (each within the scatter of the next).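

Among these compounds, the pair compound 2 and compound 3 gives the first direct reading of hydroxy in place of chloro on this aromatic carbon, para to a large group, the change from 4-chlorophenyl to 4-hydroxyphenyl: in this assay the step is a number 5.3 percentage points lower from compound 2 to compound 3 (within the scatter). The swap brings in one hydrogen-bond donor and one hydrogen-bond acceptor where the chloro group had neither, yet compound 3 still gives 91.2%, so this pair shows no effect of the change that can be told from the scatter, and a strong effect at the dose given survives it. Nothing measured here explains this outcome at this position.

Since the read-out is the size of the effect at one dose and the values of this pair lie close to the top of it, the pair cannot show whether a difference between the two groups would emerge at a lower dose. It also leaves open whether a group further removed from these two at the same position, such as an amine, a carboxylic acid or a longer alkoxy chain, would give a step beyond the scatter.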